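From thiophen-2-yl to 1,3-thiazol-2-yl on a shared core

A few compounds are considered here, and "the series" means these few. Any claim that something is new, unique, unknown or untested is made for them only; others in the source may bear on it.

In a functional assay on A549 cells (Homo sapiens), read by sulforhodamine B assay, with a stated time of 5 days (on this read-out lower numbers stand for stronger inhibition of growth and higher numbers for weaker inhibition of growth), compound 1 (`OC[C@H]1O[C@@H](n2cc(F)c3c(-c4ccco4)ncnc32)[C@H](O)[C@@H]1O`) gives 110 nM, and compound 2 (`OC[C@H]1O[C@@H](n2cc(F)c3c(-c4cccs4)ncnc32)[C@H](O)[C@@H]1O`) gives 61 nM. Within the data shown here, these are the only two numbers available, and compound 2 stands within the scatter of compound 1. Among the measured compounds shown here, the single measured step, a 1.8-fold lower number from compound 1 to compound 2 (0.26 log units; within the scatter), places thiophen-2-yl where furan-2-yl stood on an aromatic carbon.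

Compound 3 (`OC[C@H]1O[C@@H](n2cc(F)c3c(-c4nccs4)ncnc32)[C@H](O)[C@@H]1O`) keeps the core of compound 2 and carries 1,3-thiazol-2-yl in place of thiophen-2-yl on that same aromatic carbon: 1,3-thiazol-2-yl in place of thiophen-2-yl on an aromatic carbon. The measured step bears on this change, as it too exchanges one five-membered aromatic ring for another, and it stayed small. However, no measured compound has a five-membered aromatic ring with 2 hetero atoms, so that evidence is thin. Only a modest move toward weaker inhibition is therefore expected, with no clear departure from the scatter. The expected step is a 1.8-fold higher number from compound 2 to compound 3 (0.26 log units; within the scatter). For compound 3 the estimated value is 110 nM, with an expected range from 35 nM to 450 nM.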

Compound 3, concentration for 50% growth inhibition: 900 nM
Compound 3: the middle estimate sits 8.2-fold (0.91 log units) below what was measured; the whole stated range lies below it.
By their numbers in this assay, from the lowest: compounds 2 and 1 (each within the scatter of the next); then compound 3.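

In this assay, this position on the aromatic carbon next to the ring nitrogen proves less tolerant of ring exchange than the earlier pair suggested: a 1.8-fold lower number from compound 1 to compound 2 (0.26 log units; within the scatter) had stayed within the scatter, but the step to 1,3-thiazol-2-yl is a 15-fold higher number from compound 2 to compound 3 (1.17 log units; beyond the scatter). The same group also stands apart when set against furan-2-yl, with an 8.2-fold higher number from compound 1 to compound 3 (0.91 log units; beyond the scatter), so compound 3 has a clearly higher number than both earlier compounds, and among these three only compound 3 carries a five-membered aromatic ring with 2 hetero atoms. Nothing given here explains this rise in the number, and its cause remains unknown.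

With a single thiazole in hand, the compounds shown cannot separate the presence of the second ring hetero atom from its place in the ring, a question that 1,3-thiazol-4-yl, 1,3-thiazol-5-yl or 1,3-oxazol-2-yl would bear on. They also leave open how this carbon responds to groups outside the five-membered aromatic rings, such as phenyl, an amine or a short alkyl chain.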